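One Naphthyl-to-Phenyl Swap, Measured Once, Expected Again

The source may report more compounds than this note shows. Statements on the series, on what has been measured and on what is new or still open speak of the compounds shown alone.

Four compounds share one core and differ at two points: the ring hanging on the ether oxygen and the halogen on the far aromatic ring. Compound 1 `S=C(N/N=C/c1ccc(Oc2ccc3ccccc3c2)cc1)Nc1ccc(Cl)cc1` carries both the larger ring and chloro. In a physicochemical assay for lipophilicity, in phosphate buffer, measured as octanol-water partition, with a stated time of 24 h (a higher number here means a more lipophilic compound, a lower number a more polar compound), compound 1 gives 6.96. Compound 2 `S=C(N/N=C/c1ccc(Oc2ccccc2)cc1)Nc1ccc(Cl)cc1` differs from compound 1 only by phenyl in place of naphthalen-2-yl on an oxygen on an aromatic ring; in this assay compound 2 gives 5.64, which makes the step of a number 1.32 log units lower from compound 1 to compound 2 (beyond the scatter). Compound 3 `Fc1ccc(NC(=S)N/N=C/c2ccc(Oc3ccc4ccccc4c3)cc2)cc1` differs from compound 1 by fluoro in place of chloro on an aromatic carbon, so its core is the fluoro version of the chloro core of compound 1. In this assay compound 3 gives 6.2, a step of a number 0.76 log units lower from compound 1 to compound 3 (beyond the scatter).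

Compound 4 `Fc1ccc(NC(=S)N/N=C/c2ccc(Oc3ccccc3)cc2)cc1` has not yet been measured. It differs from compound 3 by phenyl in place of naphthalen-2-yl on an oxygen on an aromatic ring. The place where the swap happens is described in the same words for both pairs, so this is the same change carried over from the chloro core to the fluoro core; the cores themselves differ only as told above. The step from compound 3 to compound 4 is expected to be a number 1.30 log units lower from compound 3 to compound 4 (beyond the scatter), and this expectation rests on the earlier pair because that step was a number 1.32 log units lower from compound 1 to compound 2 (beyond the scatter). In this assay compound 4 is therefore expected to give about 4.9, most likely between 4.4 and 5.4.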

Compound 4, partition coefficient: 5.09
Compound 4: middle estimate off by 0.19 log units, on the low side, and the stated range covers the measured number.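

In this assay, putting phenyl in place of naphthalen-2-yl on the fluoro core gives a number 1.11 log units lower from compound 3 to compound 4 (beyond the scatter) and so runs the same way as on the chloro core, where the same change gave a number 1.32 log units lower from compound 1 to compound 2 (beyond the scatter) and both steps rank as large. The four compounds also close a square: fluoro in place of chloro gives a number 0.55 log units lower from compound 2 to compound 4 (beyond the scatter) with phenyl on the oxygen and a number 0.76 log units lower from compound 1 to compound 3 (beyond the scatter) with naphthalen-2-yl there, so each change lowers the number in both of its pairs, and no compound shown goes against this. Still, two cores that differ only in one halogen are a single repeat rather than a rule for the whole series, and no measurement shown explains why these steps have the sizes they do.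

Going by these compounds, only chloro and fluoro appear as the halogen, so it remains open whether the swap would carry over in the same way to a core with an amine or a carboxylic acid in that place. Only phenyl and naphthalen-2-yl stand on the oxygen, which leaves open what a longer chain there would do to the number.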